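The source may hold more compounds than are shown below. What is called first, only, known or untested is meant among the compounds shown, and "the series" means these compounds.

Compound 1 `Cc1ccccc1-n1nncc1CN1C(=O)C2(C(C#N)=C(N)Oc3c2c2nc4ccccc4nc2c2ccccc32)c2ccccc21` gives in a functional assay on HCT-116 cells (Homo sapiens) for antiproliferative activity, read by MTT assay, with a stated time of 48 h (on this read-out lower numbers stand for stronger inhibition and higher numbers for weaker inhibition), only a limit of the assay, > 50000 nM. Compound 2 `CC(=O)Nc1ccc(-n2nncc2CN2C(=O)C3(C(C#N)=C(N)Oc4c3c3nc5ccccc5nc3c3ccccc43)c3ccccc32)cc1` likewise gives only a limit, > 50000 nM. Compound 3 `N#CC1=C(N)Oc2c(c3nc4ccccc4nc3c3ccccc23)C12C(=O)N(Cc1cnnn1-c1cccc(S(N)(=O)=O)c1)c1ccccc12` gives 11300 nM.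

Among the compounds with values here, compound 3 thus holds the only actual number among the three; the other two sit at the limit (the limit of > 50000 nM in this assay, at which 2 of the 3 values shown sit). The unmeasured compound 4 `Cc1cc(C)cc(-n2nncc2CN2C(=O)C3(C(C#N)=C(N)Oc4c3c3nc5ccccc5nc3c3ccccc43)c3ccccc32)c1` differs from compound 3 by 3,5-dimethylphenyl in place of 3-sulfamoylphenyl on an aromatic nitrogen. The measured steps that bear on this run the opposite way: an at least 4.4-fold lower number from compound 1 to compound 3 (0.64 log units; beyond the scatter) and an at least 4.4-fold lower number from compound 2 to compound 3 (0.64 log units; beyond the scatter), each moving from an aryl without the sulfamoyl group to the one carrying it. Removing that group again for a 3,5-dimethylphenyl, which resembles the 2-methylphenyl of compound 1, is expected to push the number back up, probably to the limit. For compound 4 the estimate is 50000 nM (20000 nM to 200000 nM), an expected step of a 4.4-fold higher number from compound 3 to compound 4 (0.65 log units; beyond the scatter).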

Compound 4, half-maximal inhibitory concentration: > 50000 nM
Compound 4 ended at the assay's limit; the forecaster's own chance of this, stated with the estimate: 65%; the middle value sits exactly at the limit.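

The 3,5-dimethylphenyl, with 0 hydrogen-bond donors and 0 hydrogen-bond acceptors, gives a direct comparison with the 3-sulfamoylphenyl on the same aromatic nitrogen: in this assay this change gives an at least 4.4-fold higher number from compound 3 to compound 4 (0.64 log units; beyond the scatter). Among the four compounds, only compound 3 gives an actual number, and no compound goes against this. The steps among compound 1, compound 2 and compound 4 cannot be read, as all three values are limits: the limit of > 50000 nM in this assay, at which 3 of the 4 values shown sit.

From the compounds shown here alone, it remains open whether the sulfamoyl group is specifically required at this position. A carboxylic acid or an amine on the same phenyl ring could show whether other groups also give a measurable number.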